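The source may report more compounds than this note shows. Statements on the series, on what has been measured and on what is new or still open speak of the compounds shown alone.

Compound 1 `CCCCCCCCCC(CCO)n1cnc2c(Cl)nc(F)nc21`: 12500 nM
Compound 2 `O=C(OCC(CCO)n1cnc2c(Cl)nc(F)nc21)c1ccccc1`: 7240 nM

Both values come from a functional assay on SW480 cells (Homo sapiens) for antiproliferative activity, read by MTT assay, with a stated time of 48 h; a higher number here means a weaker inhibitor, a lower number a stronger inhibitor. Compound 2, at 7240 nM, lies within the usual scatter of compound 1, at 12500 nM, so these two numbers cannot be ranked. Both compounds are weak on this scale.

The next compound to be tested is compound 3 `CC(C)(C)[Si](C)(C)OCC(CCO)n1cnc2c(Cl)nc(F)nc21`. It keeps the core and side chain of compound 2 and changes one group: a group of 7 heavy atoms (6 carbon, 1 silicon; no ring) in place of a group of 8 heavy atoms (7 carbon, 1 oxygen; one six-membered aromatic ring of carbon only), on an oxygen on a saturated carbon. The benzoyl group is thus replaced by one with no ring.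

Among the measured compounds shown here, no measured pair of compounds differs in just one place, so the data give no direct guide to this change. Compound 1 at 12500 nM and compound 2 at 7240 nM do show similar values despite their different groups, so no change beyond the scatter is expected in this assay. The expected size is small, a 1.0-fold lower number from compound 2 to compound 3 (0.01 log units; within the scatter). For compound 3 the estimated value is 7000 nM, with an expected range of 2500 nM to 20000 nM.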

Compound 3, half-maximal inhibitory concentration: 8020 nM
Compound 3: middle estimate off by 1.1-fold (0.06 log units), on the low side, and the stated range covers the measured number.
By their numbers in this assay, from the lowest: compounds 2, 3 and 1 (each within the scatter of the next).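

In this assay, placing a ring-free, silicon-bearing group on this oxygen in place of benzoyl gives a 1.1-fold higher number from compound 2 to compound 3 (0.04 log units; within the scatter), so this level of activity does not depend on the aromatic ring or the carbonyl of the benzoyl group. The step on the saturated chain carbon, a 1.6-fold lower number from compound 1 to compound 3 (0.19 log units; within the scatter), likewise does not separate the all-carbon group of compound 1 from the silicon-bearing group of compound 3. Thus, three quite different groups give numbers that cannot be ranked, and no other measurement here helps to interpret this result.

On these data alone, it remains open whether any group at this position can move the number beyond the scatter. A small methyl group on this oxygen, or a chain ending in an amine or a carboxylic acid, would test that.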